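This account rests on a few compounds, and the source may have more. Where it says the series, first, only, none or still open, it means among the compounds named here.

Measured compounds:
compound 1 `COc1ccccc1C(=O)NCc1ccc(CNS(=O)(=O)c2ccc([N+](=O)[O-])cc2)cc1`, 100 nM
compound 2 `COc1ccccc1C(=O)NCc1ccc(CNS(=O)(=O)c2ccccc2C)cc1`, 1000 nM

In an assay on MDA-MB-231 cells for displacement of a labelled ligand from C-X-C chemokine receptor type 4 (Homo sapiens), read by fluorescence and microscopy, with stated times of 10 min and 30 min (on this read-out lower numbers stand for an effect already at smaller amounts and higher numbers for an effect only at larger amounts of compound), compound 1 gives 100 nM, and compound 2 gives 1000 nM. Compound 2 thus has the highest number of the two; its nearest neighbour is compound 1, separated from it by a 10-fold higher number from compound 1 to compound 2 (1.00 log units; beyond the scatter). Compound 3 `COc1ccccc1C(=O)NCc1ccc(CNS(=O)(=O)c2cccc3ccccc23)cc1` has not yet been measured. It differs from compound 2 in one place: naphthalen-1-yl in place of 2-methylphenyl on a sulfonyl sulfur. Among the measured compounds shown here, the only measured step, a 10-fold higher number from compound 1 to compound 2 (1.00 log units; beyond the scatter), also exchanges one ring for another on the same sulfonyl sulfur, but neither of its groups is the naphthalen-1-yl that enters here, so it offers no direct guide; it shows only that a change at this position can shift the number by a modest amount. For the measured compounds named here, with no closer precedent, a step of at most modest size in either direction is expected, centred near no change. Compound 3 is therefore estimated at 600 nM, with a range from 150 nM to 2500 nM. That expectation corresponds to a 1.7-fold lower number from compound 2 to compound 3 (0.22 log units; within the scatter).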

Compound 3, effective concentration (reported as EC, without a stated level of effect): > 1000 nM
Compound 3 was reported as a limit (the forecaster's own chance of this, stated with the estimate: 5%); middle value at least 1.6-fold (0.22 log units) from the limit.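

In this assay compound 3 gives > 1000 nM, which is a limit of the assay and not a number. The exchange of 2-methylphenyl for naphthalen-1-yl gives a number no lower from compound 2 to compound 3 (the limit leaves the size open) and its size therefore cannot be read: the limit of > 1000 nM in this assay, at which 1 of the 3 values shown sits. The step that can be read is an at least 10-fold higher number from compound 1 to compound 3 (1.00 log units; beyond the scatter), so a second ring group on the sulfonyl sulfur now gives a number beyond the scatter from that of compound 1, which holds the lowest number of the three.

The compounds shown leave open whether the lower number of compound 1 goes with its nitro group or with the ring alone, a question that a plain phenyl ring or a 4-cyanophenyl group on the same sulfur could address. They also leave open what a small methyl group or a ring-free amine would give there.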